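The source may report more compounds than this note shows. Statements on the series, on what has been measured and on what is new or still open speak of the compounds shown alone.

Of the compounds shown here, three that share one core have been measured in a functional assay (strain AB) with Danio rerio as the target, read by microscopy, with a stated time of 1 h; a lower number here means that less compound is needed, a higher number that more compound is needed for the effect. Compound 1 `CC(C)(C)OC(=O)CCCC[N+]1(C)CCc2c(sc(NC(=O)Nc3ccc(Cl)cc3)c2C(N)=O)C1` gives 140 nM. Compound 2 `CC(C)(C)OC(=O)CCN1CCc2c(sc(NC(=O)Nc3ccc(Cl)cc3)c2C(N)=O)C1` gives 1100 nM, which is the highest of the two numbers shown; the nearest value, that of compound 1, lies well below it, a gap beyond the usual scatter of this assay. Compound 3 `CCN1CCc2c(sc(NC(=O)C3(C(=O)Nc4ccc(Cl)cc4)CC3)c2C(N)=O)C1` gives > 25000 nM, and that value is a limit of this assay rather than a number (the limit of > 25000 nM in this assay, at which 1 of the 3 values shown sits).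

The next compound, compound 4 `CC(C)(C)OC(=O)CCCCN1CCc2c(sc(NC(=O)Nc3ccc(Cl)cc3)c2C(N)=O)C1`, differs from compound 2 in one place: 2-(tert-butoxycarbonyl)ethyl in place of tert-butoxycarbonyl on a saturated chain carbon, two bonds along the chain from an amine nitrogen in a ring. For the measured compounds named here, no measured pair in this set differs in exactly this way, so the size of the step has to be guessed. Compound 1, whose structure stands above, also carries the 4-(tert-butoxycarbonyl)butyl chain on its ring nitrogen, though in a different form, and its value of 140 nM sits well below that of compound 2. On that basis the step from compound 2 to compound 4 is expected to lower the number by more than the scatter, a 3.1-fold lower number from compound 2 to compound 4 (0.50 log units; beyond the scatter). Compound 4 is therefore estimated at 350 nM, with a likely range from 120 nM to 1000 nM.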

Compound 4, half-maximal effective concentration: 710 nM
Beside the measured number, compound 4's estimate is 2.0-fold (0.31 log units) below it; measured number inside the range.
By their numbers in this assay, from the lowest: compound 1; then compounds 4 and 2 (each within the scatter of the next). At a limit, above all of these: compound 3.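

This position accepts a longer chain without a clear change: going from 2-(tert-butoxycarbonyl)ethyl to 4-(tert-butoxycarbonyl)butyl on the amine nitrogen in a ring gives a 1.5-fold lower number from compound 2 to compound 4 (0.19 log units; within the scatter) in this assay, so these two chain lengths cannot be told apart here. Compound 1 gives 140 nM and compound 4 gives 710 nM even though both carry the 4-(tert-butoxycarbonyl)butyl chain, in a different form in compound 1, so the longer chain alone does not bring the number down to that of compound 1. Nothing measured here explains why the two chain lengths read alike.

Going by these compounds, two chain lengths cannot show a trend, so it remains open whether a still longer chain, such as 6-(tert-butoxycarbonyl)hexyl, would stay within the scatter of these values or move clearly away from them. On these data alone, it is also open whether the tert-butyl ester itself matters at this position, which a free carboxylic acid or a primary amine at the end of the same chain would test in this assay against compound 4.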